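The compounds below may be only part of what the source reports. "The series", "measured", "known", "first", "only" and "open" are said of these compounds alone.

The series rests on two measured compounds and one still to be measured. Compound 1 `CCOC(=O)CC(=O)N1CCSC1COc1ccccc1OC` gives 11 mg/kg in a functional assay on the whole organism (trachea) for inhibition, with Cavia porcellus as the target; on this read-out lower numbers stand for an effect already at smaller amounts and higher numbers for an effect only at larger amounts of compound. Compound 2 `COc1ccccc1OCC1SCCN1C(=O)CSC` gives 21 mg/kg in this assay; set beside compound 1 it shows the step of a 1.9-fold higher number from compound 1 to compound 2 (0.28 log units; within the scatter), so the two numbers cannot be told apart. Compound 3 `COc1ccccc1OCC1SCCN1C(=O)C[S+](C)[O-]` differs from compound 2 by a group of 3 heavy atoms (1 carbon, 1 oxygen, 1 sulfur; no ring) in place of a group of 2 heavy atoms (1 carbon, 1 sulfur; no ring), on a saturated chain carbon bound to a carbonyl carbon. For the measured compounds named here, only one measured step touches the same saturated chain carbon bound to a carbonyl carbon, the step of a 1.9-fold higher number from compound 1 to compound 2 (0.28 log units; within the scatter), and it stayed within the scatter. On that basis the step of a 1.2-fold higher number from compound 2 to compound 3 (0.08 log units; within the scatter) is expected to stay within the scatter as well, leaning if at all towards a higher number. Compound 3 is therefore estimated at 25 mg/kg in this assay, with a range from 10 mg/kg to 60 mg/kg.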

Compound 3, dose for half-maximal effect: 10 mg/kg
The estimate for compound 3 lay 2.5-fold (0.40 log units) above the measured number; measured number inside the range.
By their numbers in this assay, from the lowest: compounds 3, 1 and 2 (each within the scatter of the next, the first and the last beyond it).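

In this assay, for the compounds shown here, the replacement of methylsulfanyl by the group of 3 heavy atoms gives a 2.1-fold lower number from compound 2 to compound 3 (0.32 log units; beyond the scatter) and so becomes the first step at this saturated chain carbon bound to a carbonyl carbon to pass beyond the scatter, if only modestly. Ethoxycarbonyl and the group of 3 heavy atoms cannot be told apart, with a 1.1-fold lower number from compound 1 to compound 3 (0.04 log units; within the scatter) as the step between them, so the count of heavy atoms in the group does not line up with the numbers across these three compounds. Nothing available explains the shift. As far as these compounds go, how an amine or a carboxylic acid at this carbon would read remains open. So does whether the same change would hold on a longer chain or with a different group on the shared core.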